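The compounds below may be only part of what the source reports. "The series", "measured", "known", "first", "only" and "open" are said of these compounds alone.

Compound 3, `Cc1cc(C#N)cc(C)c1Oc1nc(Nc2ccc(C#N)cc2)ncc1-c1cccc2ccccc12`, is the starting point. In an ADME assay on MT4 cells (Homo sapiens) for cytotoxicity, read by MTT assay, with a stated time of 5 days (on this read-out higher numbers stand for lower toxicity in this test and lower numbers for higher toxicity in this test), compound 3 gives > 267000 nM, a reading that is a limit of the assay rather than a number. Compound 1, `Cc1cc(C#N)cc(C)c1Oc1nc(Nc2ccc(C#N)cc2)ncc1-c1ccco1`, is the furan-2-yl analogue, and in this assay compound 1 gives > 306000 nM, again a limit. Compound 2, `Cc1cc(C#N)cc(C)c1Oc1nc(Nc2ccc(C#N)cc2)ncc1-c1ccc(Cl)cc1`, carries 4-chlorophenyl and in this assay compound 2 gives 72600 nM. Among the measured steps, an at least 3.6-fold higher number from compound 2 to compound 3 (0.56 log units; beyond the scatter) and an at least 4.2-fold lower number from compound 1 to compound 2 (0.62 log units; beyond the scatter) are the two that are readable, while a step that the two limits leave unreadable from compound 1 to compound 3 cannot be sized because both ends are limits, as the limit of > 267000 nM in this assay, at which 1 of the 3 values shown sits, and the limit of > 306000 nM in this assay, at which 1 of the 3 values shown sits, show.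

Compound 4, `Cc1cc(C#N)cc(C)c1Oc1nc(Nc2ccc(C#N)cc2)ncc1-c1cccs1`, differs from compound 3 by thiophen-2-yl in place of naphthalen-1-yl on an aromatic carbon. The five-membered heteroaryl ring that enters is closest in kind to the furan-2-yl of compound 1, whose reading sits at a limit. It is therefore expected that compound 4 stays near the limit as well, with a step of an at least 1.2-fold lower number from compound 3 to compound 4 (0.08 log units; that floor lies within the scatter) that is not expected to exceed the scatter. The estimated value for compound 4 in this assay is 220000 nM, with a range from 70000 nM to 400000 nM.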

Compound 4, half-maximal cytotoxic concentration: 6430 nM
Compound 4: middle estimate off by 34-fold (1.53 log units), on the high side, outside the stated range (below it).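

In this assay, for the compounds shown here, the group on this aromatic carbon, para to the (4-cyanophenyl)amino group, matters far more than the earlier compounds showed: thiophen-2-yl in place of naphthalen-1-yl gives an at least 41-fold lower number from compound 3 to compound 4 (1.61 log units; beyond the scatter) and thiophen-2-yl in place of 4-chlorophenyl gives an 11-fold lower number from compound 2 to compound 4 (1.05 log units; beyond the scatter), leaving compound 4 with the lowest number of the four and so the highest toxicity in this test. The sharpest contrast lies between the two five-membered rings, with an at least 47-fold lower number from compound 1 to compound 4 (1.67 log units; beyond the scatter) for thiophen-2-yl in place of furan-2-yl, so a five-membered heteroaryl ring at this place does not by itself keep the reading high. Nothing shown here accounts for this drop.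

The compounds shown leave open whether the sulfur of the ring or its point of attachment goes with the low reading. As far as these compounds go, whether thiophen-3-yl or a morpholine ring at this place would read like compound 4 or like compound 1 also stays open.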